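A few compounds are considered here, and "the series" means these few. Any claim that something is new, unique, unknown or untested is made for them only; others in the source may bear on it.

In a functional assay on HepG2 cells (Homo sapiens) for inhibition, read by MTT assay, with a stated time of 24 h (on this read-out higher numbers stand for weaker inhibition and lower numbers for stronger inhibition), compound 1 (`Cc1ccc(C(=O)NCC(=O)N/N=C/c2ccccc2OCc2ccccc2Cl)cc1`) reads 13400 nM. Compound 2 (`COc1ccc(/C=N/NC(=O)CNC(=O)c2ccc(F)cc2)c(OCc2ccccc2Cl)c1`) reads 15700 nM, and these two values lie within the usual scatter of each other, so neither can be ranked over the other. Compound 3 (`O=C(CNc1ccccc1)N/N=C/c1ccc(OCc2ccc(F)cc2)c(Cl)c1`) gives 27400 nM, a number higher than that of compound 1 by a margin just beyond the scatter. Compound 1 therefore stands at the low end of this small set, level with compound 2.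

The unmeasured compound 4 (`Cc1ccc(C(=O)NCC(=O)N/N=C/c2ccccc2OCc2ccc(C#N)cc2)cc1`) keeps the core of compound 1 and changes one place, on a saturated chain carbon bound to an oxygen on an aromatic ring: 4-cyanophenyl in place of 2-chlorophenyl on a saturated chain carbon bound to an oxygen on an aromatic ring. In other words, 2-chlorobenzyl gives way to 4-cyanobenzyl.

For the measured compounds named here, no two measured compounds differ in only one place, so the data give no direct measure of such a swap. Going by the values given here, the only guide is the narrow spread of the set, which runs from compound 1 at 13400 nM to compound 3 at 27400 nM. In this assay, a small step towards a higher number is therefore expected, probably none beyond the scatter. The estimated step is a 1.3-fold higher number from compound 1 to compound 4 (0.10 log units; within the scatter). For compound 4, the expected value is 17000 nM, with an estimated range from 8000 nM to 35000 nM.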

Compound 4, half-maximal inhibitory concentration: > 50000 nM
Compound 4 was reported as a limit; the forecaster's own chance of this, stated with the estimate: 5%; middle value at least 2.9-fold (0.46 log units) away from the limit.
By their numbers in this assay, from the lowest: compounds 1, 2 and 3 (each within the scatter of the next, the first and the last beyond it). At a limit, above all of these: compound 4.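

For the compounds shown here, at the place named here, a saturated chain carbon bound to an oxygen on an aromatic ring, 4-cyanophenyl in place of 2-chlorophenyl gives the first single-place comparison in this set, and in this assay it produces an at least 3.7-fold higher number from compound 1 to compound 4 (0.57 log units; beyond the scatter). The earlier compounds shown here stayed within a narrow spread and could not show that the aromatic ring at this place matters to the read-out, but this pair shows that it can. Compound 4 is reported only as a limit, not as a number, so the full size of the step remains unknown: the limit of > 50000 nM in this assay, at which 1 of the 4 values shown sits.

The swap replaces the 2-chlorophenyl group as a whole, so this single pair cannot separate the loss of the chlorine from the entry of the nitrile, nor either of these from the change in where the substituent sits on the ring. It also leaves open whether plain phenyl, or a phenyl carrying an amine or a carboxylic acid, would read closer to compound 1 or to compound 4 at this place on the shared core.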